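Thiourea series: methoxy for chloro on the benzoyl ring

The source may report more compounds than this note shows. Statements on the series, on what has been measured and on what is new or still open speak of the compounds shown alone.

Measured so far in a functional assay on HL-60 cells (Homo sapiens) for antiproliferative activity, with a stated time of 24 h; on this read-out higher numbers stand for weaker inhibition and lower numbers for stronger inhibition:
compound 1 `NC(=O)c1c(NC(=O)c2ccccc2Cl)sc2c1CCN(C(=S)Nc1ccccc1F)C2`, 4970 nM
compound 2 `COc1ccccc1NC(=S)N1CCc2c(sc(NC(=O)c3ccccc3Cl)c2C(N)=O)C1`, 40900 nM
compound 3 `NC(=O)c1c(NC(=O)c2ccccc2Cl)sc2c1CCN(C(=S)Nc1ccccc1-c1ccccc1)C2`, 34400 nM

Compound 2 gives the highest of the three numbers in this assay. Compound 1 lies at an 8.2-fold higher number from compound 1 to compound 2 (0.92 log units; beyond the scatter); compound 3 and compound 2 sit within the scatter of each other.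

Compound 4 `COc1ccccc1NC(=S)N1CCc2c(sc(NC(=O)c3ccccc3OC)c2C(N)=O)C1` differs from compound 2 by methoxy in place of chloro on an aromatic carbon, that is, (2-chlorophenyl)carbonyl to (2-methoxyphenyl)carbonyl, ortho to a large group. Among the compounds with values here, none of the measured steps touches this ring; all vary the aryl on the thiourea. Within the data shown here, there is thus no step to lean on, and no change beyond the scatter is expected: a 1.0-fold lower number from compound 2 to compound 4 (0.01 log units; within the scatter). Compound 4 is estimated at 40000 nM, range 12000 nM to 130000 nM.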

Compound 4, half-maximal inhibitory concentration: > 50000 nM
Compound 4 ended at the assay's limit (the forecaster's own chance of this, stated with the estimate: 20%); at least 1.2-fold (0.09 log units) between middle value and limit.
By their numbers in this assay, from the lowest: compound 1; then compounds 3 and 2 (each within the scatter of the next). At a limit, above all of these: compound 4.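

In this assay compound 4 gives a limit of the assay and not a number: > 50000 nM.

The step reads an at least 1.2-fold higher number from compound 2 to compound 4 (0.08 log units; that floor lies within the scatter), so methoxy in place of chloro on this ring brings no lower number, while its true size stays unreadable. This is the only change shown on the (2-chlorophenyl)carbonyl group, and its value alone rests at the limit: the limit of > 50000 nM in this assay, at which 1 of the 4 values shown sits.

From the compounds shown here alone, whether methoxy in place of chloro reads the same with the fluoro-bearing thiourea aryl of compound 1 stays open. So does what an amine or a carboxylic acid would give in place of chloro here.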